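The source may report more compounds than this note shows. Statements on the series, on what has been measured and on what is new or still open speak of the compounds shown alone.

Measured compounds:
compound 1 `COC(=O)C1=C(C)NC(=O)NC1c1ccoc1` — 2%
compound 2 `COC(=O)C1=C(C)N(C)C(=O)NC1c1ccoc1` — 7%
compound 3 `CC1=C(C(=O)OCC(C)C)C(c2ccoc2)NC(=O)N1C` — 16%

In an assay on membranes from HeLa cells for displacement of a labelled ligand from adenosine receptor A3 (Homo sapiens), read by scintillation counting, with a stated time of 180 min, tested at 1 uM (on this read-out lower numbers stand for less inhibition and higher numbers for more inhibition at the one concentration tested (going by the name of the read-out)), compound 2 gives 7%. This is the second highest of the three numbers, but all three lie within the usual scatter of one another: the step of a number 5 percentage points higher from compound 1 to compound 2 (within the scatter) and the step of a number 9 percentage points higher from compound 2 to compound 3 (within the scatter) are both within the scatter, so no order among compound 1, compound 2 and compound 3 can be claimed from these numbers.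

Compound 4 `COC(=O)C1=C(C)N(C)C(=O)NC1c1ccsc1` is not yet measured. It differs from compound 2 in one place: thiophen-3-yl in place of furan-3-yl on a saturated ring carbon

Among the compounds with values here, none of the measured steps touches the group on the saturated ring carbon; they change a methyl on an amide-type nitrogen in the ring and an isopropyl on the chain carbon bound to an oxygen next to the carbonyl group, and neither produced a change beyond the scatter. There is therefore no direct guide for this change, and the safest reading is that swapping one five-membered aromatic ring with one hetero atom for another of the same size will leave the read-out roughly where compound 2 stands. The expected step is a number 2 percentage points higher from compound 2 to compound 4 (within the scatter), which means no shift beyond the scatter. Compound 4 is estimated at 9%, with a range from 0% to 22%.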

Compound 4, a percentage reported as inhibition, at one concentration (the size of the read-out at that concentration, not a potency): 22%
Compound 4: middle estimate off by 13 percentage points, on the low side; low and high end bracket the measured number.
By their numbers in this assay, from the lowest: compounds 1, 2, 3 and 4 (each within the scatter of the next, the first and the last beyond it).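

In this assay, within the data shown here, putting thiophen-3-yl in place of furan-3-yl on the saturated ring carbon gives a number 15 percentage points higher from compound 2 to compound 4 (beyond the scatter), the first single change in this set to go beyond the scatter and the first to touch this position. The two groups match in every count given here: each has 5 heavy atoms, forms one five-membered aromatic ring with 1 hetero atom, and has the same numbers of hydrogen-bond donors and acceptors, so sulfur in place of oxygen in the ring is the one difference between them. The read-out at this position can therefore shift with the exchange of that single ring atom, although nothing available explains why this step occurs.

A single pair cannot show whether the same swap would give a similar step with the hydrogen of compound 1 on the ring nitrogen or with the longer ester chain of compound 3. It also leaves open how the read-out would respond at this ring carbon to a different group, such as phenyl, a pyridine ring or thiophen-2-yl.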